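A few compounds are considered here, and "the series" means these few. Any claim that something is new, unique, unknown or untested is made for them only; others in the source may bear on it.

In an ADME assay on microsomes from liver (Mus musculus) for metabolic stability, tested at 5 uM (a higher number here means that the compound lasts longer, a lower number that the compound disappears faster), compound 1 (`CCCCCCCCNc1ccc(C(=O)O)cc1S(N)(=O)=O`) gives 0.3 h and compound 2 (`CCCCCCCCNc1ccc(C(=O)O)cc1S(=O)(=O)NC`) gives 0.2 h while compound 3 (`CCCCCCCCNc1ccc(C(=O)O)cc1S(=O)(=O)N(C)C`) gives 0.217 h and so stands level with both others within the scatter. The next step leads to compound 4 (`COCCNc1ccc(C(=O)O)cc1S(=O)(=O)N(C)C`) and alters the chain instead: methoxy in place of hexyl on a saturated chain carbon, two bonds along the chain from a nitrogen on an aromatic ring. Cut one bond further out, this reads octyl to 2-methoxyethyl.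

The measured steps all concern the sulfonamide nitrogen: a 1.5-fold lower number from compound 1 to compound 2 (0.18 log units; within the scatter) and a 1.4-fold lower number from compound 1 to compound 3 (0.14 log units; within the scatter) and a 1.1-fold higher number from compound 2 to compound 3 (0.04 log units; within the scatter) each stay within the scatter. None of them touches the chain, so they give no direct guide to this change. Exchanging so much of the chain is a far larger alteration, so a longer half-life beyond the scatter is expected, though only as a judgement. The expected size is a 5.5-fold higher number from compound 3 to compound 4 (0.74 log units; beyond the scatter) in this estimate. In this assay compound 4 is estimated at 1.2 h with a range of 0.35 h to 4 h (an expectation, not a measurement).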

Compound 4, half-life in the Mus musculus assay: > 1 h
Compound 4 was reported as a limit; the forecaster's own chance of this, stated with the estimate: 15%; the middle value is on the limit's open side.
By their numbers in the Mus musculus assay, from the lowest: compounds 2, 3 and 1 (each within the scatter of the next). At a limit, above all of these: compound 4.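

On the earlier compounds, changes at the sulfonamide nitrogen stayed within the scatter in the Mus musculus assay, so the chain is the first place shown where a change clearly moves the half-life, with octyl to 2-methoxyethyl giving an at least 4.6-fold higher number from compound 3 to compound 4 (0.66 log units; beyond the scatter). The result for compound 4 is a limit, not a number: the limit of > 1 h in the Mus musculus assay, at which 1 of the 4 values shown sits. The same exchange of hexyl for methoxy also comes with a clear rise in a physicochemical assay for solubility, in phosphate buffer, measured as kinetic solubility, at pH 7.4, tested at 250 uM; a higher number here means a more soluble compound, a lower number a less soluble compound: the measured solubility of compound 3, 52000 nM, and of compound 4, 237000 nM, a 4.6-fold higher number (0.66 log units; beyond the scatter). In the physicochemical assay compound 3 gives 52000 nM and compound 4 gives 237000 nM.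

Octyl and 2-methoxyethyl differ both in chain size and in the oxygen, so these compounds cannot separate the two, and a plain butyl chain, without oxygen, or a 2-hydroxyethyl chain could help to do so. Going by these compounds, it also remains open whether the sulfonamide nitrogen still makes so little difference once the 2-methoxyethyl chain is in place.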